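Bromo anilide of the nitrophenyl pyrazole

The compounds below may be only part of what the source reports. "The series", "measured", "known", "first", "only" and "open" are said of these compounds alone.

Measured compounds:
compound 1 `O=C(Nc1ccc(Br)cc1)c1cn(-c2ccccc2)nc1-c1ccccc1`, 5750 nM
compound 2 `COc1ccc(-c2nn(-c3ccccc3)cc2C(=O)Nc2ccc(Br)cc2)cc1`, 8210 nM
compound 3 `O=C(Nc1ccccc1)c1cn(-c2ccccc2)nc1-c1ccc([N+](=O)[O-])cc1`, 2260 nM

Of the compounds shown here, three share a core and have been tested in a functional assay on MCF7 cells (Homo sapiens) for cytotoxicity, read by MTT assay, with a stated time of 48 h; on this read-out higher numbers stand for weaker inhibition and lower numbers for stronger inhibition. Compound 3 gives the lowest number of the three, 2260 nM, and its steps to compound 1 and to compound 2 both lie beyond the scatter, so on these numbers compound 3 is the most potent. Among the measured compounds shown here, the only step between compounds differing in one place is a 1.4-fold higher number from compound 1 to compound 2 (0.15 log units; within the scatter), which concerns the other aryl ring and lies within the scatter.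

Compound 4 `O=C(Nc1ccc(Br)cc1)c1cn(-c2ccccc2)nc1-c1ccc([N+](=O)[O-])cc1` differs from compound 3 by bromo in place of hydrogen on an aromatic carbon. For the measured compounds named here, no measured step bears on this change directly; compound 1 carries the same bromo group, but it also lacks the nitro group of compound 3, and those two values cannot be separated into single changes. Going by the values given here, the one single-place step measured here was within the scatter, and nothing in these data points to a large effect of a substituent on either outer ring. Compound 4 is therefore expected to stay close to compound 3 in this assay, with an estimated step of a 1.0-fold lower number from compound 3 to compound 4 (0.01 log units; within the scatter). The estimate for compound 4 is 2200 nM, with a range from 800 nM to 6000 nM.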

Compound 4, half-maximal inhibitory concentration: 5300 nM
For compound 4 the middle estimate is 2.4-fold (0.38 log units) below the measured one; low and high end bracket the measured number.
By their numbers in this assay, from the lowest: compound 3; then compounds 4, 1 and 2 (each within the scatter of the next).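

In this assay, among the compounds shown here, the change from phenylcarbamoyl to (4-bromophenyl)carbamoyl gives a 2.3-fold higher number from compound 3 to compound 4 (0.37 log units; beyond the scatter), the first single-place step in this set that lies beyond the scatter, so a substituent on this ring can shift the number. With bromo held in place, the other aryl ring shows no such shift: nitro in place of hydrogen gives a 1.1-fold lower number from compound 1 to compound 4 (0.04 log units; within the scatter), and nitro in place of methoxy gives a 1.5-fold lower number from compound 2 to compound 4 (0.19 log units; within the scatter), so the three bromo anilides cannot be told apart, and the low number of compound 3 appears only with the unsubstituted anilide. No supporting measurement accounts for these steps.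

The compounds shown do not tell whether the rise in the number is particular to bromo or would also follow from a methoxy group, an amine or a carboxylic acid on the same carbon. They also leave open how much the nitro group itself contributes when the anilide ring carries hydrogen, since compound 3 has no partner with hydrogen in place of its nitro group.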